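Swapping an acrylamide for a bromoethyl ketone

A few compounds are considered here, and "the series" means these few. Any claim that something is new, unique, unknown or untested is made for them only; others in the source may bear on it.

Compound 1, `CCCCCCc1ccc(C(=O)CCN(C(C)C)C(C)C)cc1`: 4100 nM
Compound 2, `C/C=C/C(=O)Nc1ccc(CCCCCC)cc1`: > 100000 nM
Compound 3, `CCCCCCc1ccc(NC(=O)C=C(C)C)cc1`: > 100000 nM

In an assay on isolated protein for displacement of a labelled ligand from thyroid hormone receptor alpha (Homo sapiens), read by fluorescence polarization (a higher number here means a weaker inhibitor, a lower number a stronger inhibitor), compound 2 gives only a limit, > 100000 nM. Compound 3 likewise gives only a limit, > 100000 nM. Among the compounds with values here, the one measured step, a step that the two limits leave unreadable from compound 2 to compound 3, cannot be read because of the limit of > 100000 nM in this assay, at which 2 of the 3 values shown sit. Compound 4, `CCCCCCc1ccc(C(=O)CCBr)cc1`, changes the group on the shared core: (2-bromoethyl)carbonyl in place of ((prop-1-en-1-yl)carbonyl)amino on an aromatic carbon. Within the data shown here, no measured step covers this exchange. Compound 1, which also carries a carbonyl directly on the core, gives 4100 nM, a real number rather than a limit. Compound 4 is therefore expected to show measurable binding, with an estimate of 12000 nM, between 2500 nM and 70000 nM. The expected step is an at least 8.3-fold lower number from compound 2 to compound 4 (0.92 log units; beyond the scatter), toward stronger binding.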

Compound 4, half-maximal inhibitory concentration: 4200 nM
For compound 4 the middle estimate is 2.9-fold (0.46 log units) above the measured one; measured number inside the range.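

In this assay, within the data shown here, placing (2-bromoethyl)carbonyl on the aromatic carbon in place of ((prop-1-en-1-yl)carbonyl)amino gives a large gain, the first readable change at this position: an at least 23-fold lower number from compound 2 to compound 4 (1.37 log units; beyond the scatter). Further along the chain, the exchange of diisopropylamino for bromo makes no difference that can be told from scatter: a 1.0-fold higher number from compound 1 to compound 4 (0.01 log units; within the scatter). Binding at this position therefore tolerates two very different groups on that chain carbon.

The exchange from compound 2 alters several atoms at once, so which of them accounts for the gain stays open. From the compounds shown here alone, whether a carboxylic acid or a smaller amine on that chain carbon would also be tolerated stays open too.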